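Moving and Changing the Acid-Bearing Pyridine Substituent

This account rests on a few compounds, and the source may have more. Where it says the series, first, only, none or still open, it means among the compounds named here.

Measured so far:
- compound 1, `CCOC(=O)c1cccc(-c2cnc(C(=O)CCc3ccc(-c4ccccc4)cc3)o2)n1`, 3 nM
- compound 2, `NC(=O)c1cccc(-c2cnc(C(=O)CCc3ccc(-c4ccccc4)cc3)o2)n1`, 1.2 nM
- compound 3, `O=C(CCc1ccc(-c2ccccc2)cc1)c1ncc(-c2cccc(-c3nnn[nH]3)n2)o1`, 25 nM

In an assay for inhibition of Fatty-acid amide hydrolase 1 (Rattus norvegicus) (a lower number here means a stronger inhibitor, a higher number a weaker inhibitor), compound 2 gives the lowest of the three numbers; its nearest neighbour is compound 1, and the step of a 2.5-fold lower number from compound 1 to compound 2 (0.40 log units; beyond the scatter) lies beyond the scatter, as does the far larger step a 21-fold higher number from compound 2 to compound 3 (1.32 log units; beyond the scatter).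

Compound 4 is `O=C(O)c1ccc(-c2cnc(C(=O)CCc3ccc(-c4ccccc4)cc3)o2)nc1`. Its change from compound 2 is 5-carboxypyridin-2-yl in place of 6-carbamoylpyridin-2-yl on an aromatic carbon. For the measured compounds named here, no measured step covers this exact exchange. The step that comes closest is the one that also removes the carbamoyl group, a 21-fold higher number from compound 2 to compound 3 (1.32 log units; beyond the scatter), and the related step of an 8.3-fold higher number from compound 1 to compound 3 (0.92 log units; beyond the scatter) points the same way. Both suggest that leaving the carbamoyl-bearing pyridine of compound 2 costs potency, though the new carboxy group sits in a different place on the ring, so the size is uncertain.

For compound 4 the expected step is a 13-fold higher number from compound 2 to compound 4 (1.10 log units; beyond the scatter), a clear loss but smaller than that seen for compound 3. Compound 4 is therefore estimated at 15 nM, with a range from 4 nM to 60 nM.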

Compound 4, inhibition constant: 14 nM
For compound 4 the middle estimate is 1.1-fold (0.03 log units) above the measured one, within the range that was stated.
By their numbers in this assay, from the lowest: compound 2; then compound 1; then compounds 4 and 3 (each within the scatter of the next).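

In this assay, putting 5-carboxypyridin-2-yl in place of 6-carbamoylpyridin-2-yl gives a 12-fold higher number from compound 2 to compound 4 (1.07 log units; beyond the scatter), so this position on the shared core tolerates this exchange poorly even though the two groups match in their computed counts of heavy atoms, hydrogen-bond donors and hydrogen-bond acceptors. Compound 4 also lies within the scatter of compound 3, so two different replacements for the carbamoyl-bearing pyridine of compound 2 end up with numbers that cannot be told apart. Nothing available explains this step.

The exchange changes both the group and its place on the pyridine, so the compounds shown leave open how much of the step belongs to each. That would need a carboxylic acid where compound 2 carries its carbamoyl group, or a carbamoyl group where compound 4 carries its carboxy group.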